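Cyclohexyl to 2-chlorophenyl: expected cytotoxicity of compound 3

A few compounds are considered here, and "the series" means these few. Any claim that something is new, unique, unknown or untested is made for them only; others in the source may bear on it.

Measured compounds:
compound 1 `CN1CCN(CCNCc2cn(-c3ccc(C(F)(F)F)cc3)nc2-c2ccc(OC(F)(F)F)cc2)CC1`: 3000 nM
compound 2 `CN1CCN(CCNCc2cn(-c3ccc(F)cc3F)nc2C2CCCCC2)CC1`: > 20000 nM

In an ADME assay on Huh-7 cells (Homo sapiens) for cytotoxicity (a higher number here means that more compound is tolerated, a lower number that less compound is tolerated), compound 1 gives 3000 nM. Compound 2 gives no number in this assay but only a limit, > 20000 nM (the limit of > 20000 nM in this assay, at which 1 of the 2 values shown sits). Compound 3 `CN1CCN(CCNCc2cn(-c3ccc(F)cc3F)nc2-c2ccccc2Cl)CC1` differs from compound 2 by 2-chlorophenyl in place of cyclohexyl on an aromatic carbon. For the measured compounds named here, no step between measured compounds exists here, so the expectation rests only on the two values shown: compound 1, which also carries an aromatic ring at that place, gives a number where compound 2 gives a limit. Compound 3 is therefore estimated at 10000 nM (range 3000 nM to 30000 nM), a moderate fall from compound 2, with the expected step of an at least 2.0-fold lower number from compound 2 to compound 3 (0.30 log units; that floor lies within the scatter) and a fair chance that this assay again reports only a limit.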

Compound 3, half-maximal cytotoxic concentration: > 20000 nM
Compound 3 ended at the assay's limit; the forecaster's own chance of this, stated with the estimate: 35%; middle value at least 2.0-fold (0.30 log units) away from the limit.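

Compound 2 and compound 3 both give only a limit in this assay, so no step can be read between them: the limit of > 20000 nM in this assay, at which 2 of the 3 values shown sit.

From the compounds shown here alone, how far each compound lies beyond that limit, and what 2-chlorophenyl in place of cyclohexyl changes, stays open.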